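The source may hold more compounds than are shown below. What is called first, only, known or untested is meant among the compounds shown, and "the series" means these compounds.

Compound 3, with the structure `Cc1cccc(NC(=O)c2cccc(/C=C3\CC(=O)N(c4ccccc4)C3=O)c2)c1`, is one of three close relatives carrying the same core, and in an ADME assay on HCT-116 cells (Homo sapiens) for cytotoxicity, read by MTT assay, with a stated time of 72 h (a higher number here means a weaker inhibitor, a lower number a stronger inhibitor), compound 3 gives only a limit, > 100000 nM. Compound 1, `O=C(NCC1CCCCC1)c1cccc(/C=C2\CC(=O)N(c3ccccc3)C2=O)c1`, also reaches only a limit in this assay, > 100000 nM. Compound 2, `COc1ccc(OC)c(NC(=O)c2cccc(/C=C3\CC(=O)N(c4ccccc4)C3=O)c2)c1`, likewise stops at a limit in this assay, > 100000 nM. Because of this, (the limit of > 100000 nM in this assay, at which 3 of the 3 values shown sit), none of the three steps can be read: a step that the two limits leave unreadable from compound 1 to compound 2, a step that the two limits leave unreadable from compound 1 to compound 3 and a step that the two limits leave unreadable from compound 2 to compound 3 all stay unreadable in size. Compound 4, `CCc1ccc(NC(=O)c2cccc(/C=C3\CC(=O)N(c4ccccc4)C3=O)c2)cc1`, has not yet been measured in this assay. Its difference from compound 3 is 4-ethylphenyl in place of 3-methylphenyl on an amide-type nitrogen. Among the compounds with values here, no measured step bears on this change, since every step among compounds 1, 2 and 3 is hidden by the limit, so nothing beyond the scatter is expected from the step that the limit leaves unreadable from compound 3 to compound 4. On that basis compound 4 is estimated at 150000 nM in this assay, within a range from 60000 nM to 400000 nM, and it is expected most often to return only a limit again.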

Compound 4, half-maximal inhibitory concentration: > 100000 nM
Compound 4 gave a limit, no number; the forecaster's own chance of this, stated with the estimate: 85%; the middle value lies beyond the limit too.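

Compound 4 gives only a limit in this assay, > 100000 nM, and none of its steps to compound 1, compound 2 or compound 3 can be read: the limit of > 100000 nM in this assay, at which 4 of the 4 values shown sit.

The compounds shown leave open whether any group on the amide-type nitrogen of the shared core would give a measurable value in this assay.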